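The compounds below may be only part of what the source reports. "The series", "measured", "known", "first", "only" and "open" are said of these compounds alone.

The series starts from the shared core of compound 1, whose structure is `O=C(Nc1cccc(-n2cc(-c3ccncc3)c(-c3ccc(Cl)c(O)c3)n2)c1)Nc1cccc(C(F)(F)F)c1`. In a functional assay on NCI-H522 cells (Homo sapiens) for inhibition, read by sulforhodamine B assay, with a stated time of 48 h (a lower number here means a stronger inhibitor of growth, a higher number a weaker inhibitor of growth), compound 1 gives 14500 nM. Compound 2, with the structure `COc1cc(-c2nn(-c3cccc(NC(=O)Nc4cc(C(F)(F)F)cc(C(F)(F)F)c4)c3)cc2-c2ccncc2)ccc1Cl`, gives in this assay 1800 nM, and compound 3, with the structure `COc1cc(-c2nn(-c3cccc(NC(=O)c4cccc(C(F)(F)F)c4)c3)cc2-c2ccncc2)ccc1Cl`, gives in this assay 3850 nM. Among these three numbers compound 3 stands second highest: compound 2 sits nearest to it, with a lower number that lies beyond the scatter, while compound 1 is furthest from it, with a higher number that also lies beyond the scatter.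

The step from compound 3 leads to compound 4, whose structure is `COc1cc(-c2nn(-c3cccc(NC(=O)c4ccc(Cl)c(C(F)(F)F)c4)c3)cc2-c2ccncc2)ccc1Cl`. The change is chloro in place of hydrogen on an aromatic carbon, on an aromatic carbon of a six-membered aromatic ring of carbon only, ortho to a trifluoromethyl group and para to a large group. Among the compounds with values here, no measured pair in this set shows this exact change, so the size of the step is open. Compound 4 is expected to give a number in this assay that is close to that of compound 3, with the step from compound 3 to compound 4 estimated at a 1.5-fold lower number from compound 3 to compound 4 (0.17 log units; within the scatter), within or only just beyond the scatter. The estimate for compound 4 in this assay is 2600 nM, between 1000 nM and 6500 nM.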

Compound 4, concentration for total growth inhibition: 13400 nM
Beside the measured number, compound 4's estimate is 5.2-fold (0.71 log units) below it; measured number above the stated range.
By their numbers in this assay, from the lowest: compound 2; then compound 3; then compounds 4 and 1 (each within the scatter of the next).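

In this assay, the change from 3-(trifluoromethyl)phenyl to 4-chloro-3-(trifluoromethyl)phenyl gives a 3.5-fold higher number from compound 3 to compound 4 (0.54 log units; beyond the scatter), so this single added chlorine weakens growth inhibition by a step that lies beyond the scatter. Within the data shown here, this is the first pair in the set that differs in only one place, and it gives the first direct reading of this position, ortho to a trifluoromethyl group and para to a large group; the earlier compounds differ from one another in more than one place and could not isolate such an effect. No measurement shown here bears on why the position responds to chloro in this way.

The compounds shown leave open whether the loss belongs to chloro alone or would also follow a fluoro, methyl or methoxy group at this position. Going by these compounds, this change is read on a single pair, so it also remains open whether the same step would appear with a urea linker, as in compound 1 and compound 2, rather than the amide linker of compound 3.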